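A Methyl Branch Added to Two Different Side Chains

The source may hold more compounds than are shown below. What is called first, only, known or untested is meant among the compounds shown, and "the series" means these compounds.

Measured compounds:
Compound 1, `CCCOC(=O)C1=C(C)N(C)C(=O)NC1c1ccoc1`: 2%
Compound 2, `CC1=C(C(=O)OCC(C)C)C(c2ccoc2)NC(=O)N1C`: 1%
Compound 3, `CCNC(=O)C1=C(C)NC(=O)NC1c1ccoc1`: 2%

All three were tested in an assay on membranes from HEK293 cells for displacement of a labelled ligand from adenosine receptor A2b (Homo sapiens), read by scintillation counting, with a stated time of 30 min, tested at 1 uM; a higher number here means more inhibition at the concentration tested (going by the name of the read-out), a lower number less inhibition. Compound 1 gives 2% in this assay. Compound 2 differs from compound 1 by methyl in place of hydrogen on a saturated chain carbon bound to two saturated chain carbons, and this change gave a number 1 percentage points lower from compound 1 to compound 2 (within the scatter). Compound 3 shows 2% in this assay; the difference between its core and that of compound 1 is not broken down here.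

Compound 4, `CC1=C(C(=O)NC(C)C)C(c2ccoc2)NC(=O)N1`, has not yet been measured. It differs from compound 3 by methyl in place of hydrogen on a saturated chain carbon bound to an amide-type nitrogen and a saturated chain carbon. Going by the values given here, this is the same kind of change as the one from compound 1 to compound 2, but not the same: there the carbon carrying the new methyl was bound to two saturated chain carbons, here it is bound to an amide-type nitrogen and a saturated chain carbon.

Because a number 1 percentage points lower from compound 1 to compound 2 (within the scatter) stayed within the scatter, the step of no change at the digits printed from compound 3 to compound 4 (within the scatter) is expected to be similarly small. Compound 4 is therefore estimated at 2%, with a range from -8% to 12%.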

Compound 4, a percentage reported as inhibition, at one concentration (the size of the read-out at that concentration, not a potency): 3%
Beside the measured number, compound 4's estimate is 1 percentage points below it, within the range that was stated.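

In this assay, adding the methyl gave a number 1 percentage points higher from compound 3 to compound 4 (within the scatter), and this step can be set beside the earlier one on the other core: the same change on two cores in this assay, a number 1 percentage points lower (within the scatter) from compound 1 to compound 2 and a number 1 percentage points higher (within the scatter) from compound 3 to compound 4, 2 percentage points apart, within the scatter of two such steps. In these two pairs, then, the change carries from one core to the other with no difference that can be told from the scatter, even though the carbon taking the methyl is bound to two saturated chain carbons in one pair and to an amide-type nitrogen and a saturated chain carbon in the other. This does not show that the methyl is unimportant for the receptor in general: all four compounds give small numbers at a single concentration, so the two steps say little about how the same change would behave on a compound with clear inhibition.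

The compounds shown leave open whether a larger group on that carbon, such as a longer chain, a phenyl ring or an amine, would move the number beyond the scatter. They also leave open whether the two cores would still respond alike to such a group.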